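The compounds below may be only part of what the source reports. "The series", "measured", "known", "first", "only" and "open" are said of these compounds alone.

- Compound 1 `CN1C/C(=C\c2cccs2)C(O)/C(=C/c2cccs2)C1`: > 100000 nM
- Compound 2 `CN1C/C(=C\c2cccs2)C2=NN(C)C(c3cccs3)C2C1`: 59500 nM

Among the compounds with values here, in a functional assay on cells (Panel prostate (Carcinoma cell lines), Homo sapiens) for inhibition (on this read-out lower numbers stand for stronger inhibition of growth and higher numbers for weaker inhibition of growth), compound 2 gives 59500 nM, the only actual number so far. For compound 1, the result > 100000 nM is a limit of the assay. Compound 3 `CN1C/C(=C\c2cccs2)C2=NN(c3ccccc3)C(c3cccs3)C2C1` is the next to be tested and differs from compound 2 by phenyl in place of methyl on an amine nitrogen in a ring. Within the data shown here, no measured pair shows what this swap does, so only a modest gain in inhibition of growth is expected, and the estimate stays wide. The expected change is a 2.0-fold lower number from compound 2 to compound 3 (0.30 log units; within the scatter). For compound 3, the estimated value is 30000 nM, within an expected range of 8000 nM to 100000 nM.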

Compound 3, concentration for 50% growth inhibition: 19300 nM
Compound 3: the middle estimate sits 1.6-fold (0.19 log units) above what was measured; the measured number falls inside the stated range.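

In this assay, the amine nitrogen in a ring accepts more than methyl: phenyl in its place gives a 3.1-fold lower number from compound 2 to compound 3 (0.49 log units; beyond the scatter). Within the data shown here, this is the first measured change at this position, and it links one six-membered aromatic ring of carbon only with stronger inhibition of growth. Compound 1 gives only a limit of the assay and enters no step: the limit of > 100000 nM in this assay, at which 1 of the 3 values shown sits.

A single swap does not separate the effect of the aromatic ring from that of the added carbon atoms. The compounds shown also leave open how a benzyl group, a pyridine ring or a phenyl carrying chlorine would read at this nitrogen.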